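From 5-cyanopyridin-2-yl to 4-cyanophenyl on a shared core

A few compounds are considered here, and "the series" means these few. Any claim that something is new, unique, unknown or untested is made for them only; others in the source may bear on it.

Measured so far in an ADME assay on microsomes from liver (Homo sapiens) for metabolic stability; on this read-out higher numbers stand for a longer-lived compound and lower numbers for a shorter-lived compound:
Compound 1 `COc1cc(OCc2cccc(-c3ccc(C#N)cn3)c2)c2cc(-c3cn4nc(OC)sc4n3)oc2c1` gives 1.57 h
Compound 2 `CNC(=O)c1ccc(-c2nc(COc3cc(OC)cc4oc(-c5cn6nc(OC)sc6n5)cc34)cs2)cc1` gives 0.983 h
Compound 3 `COc1cc(OCc2csc(-c3ccccc3)n2)c2cc(-c3cn4nc(OC)sc4n3)oc2c1` gives 1.33 h

Compound 1 stands level with the other two. The gaps from it to compound 2 and to compound 3 lie within the usual scatter of repeated measurements, so these three values cannot be ranked.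

Compound 4 `COc1cc(OCc2cccc(-c3ccc(C#N)cc3)c2)c2cc(-c3cn4nc(OC)sc4n3)oc2c1` keeps the core of compound 1 and differs in one place, with 4-cyanophenyl in place of 5-cyanopyridin-2-yl on an aromatic carbon. For the measured compounds named here, no measured pair makes this exact swap. Going by the values given here, the only single-place step available concerns a different group, hydrogen in place of methylcarbamoyl on an aromatic carbon (a 1.4-fold higher number from compound 2 to compound 3 (0.13 log units; within the scatter)), and it stayed within the scatter. That evidence is indirect, but it gives no reason to expect a step beyond the scatter in this assay or to favour a direction. The expected step is small (a 1.1-fold lower number from compound 1 to compound 4 (0.05 log units; within the scatter)), and this remains an estimate. For compound 4 the estimated value is 1.4 h (expected range 0.7 h to 2.8 h).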

Compound 4, half-life: > 2 h
Compound 4: no number, only a limit; the forecaster's own chance of this, stated with the estimate: 10%; middle value at least 1.4-fold (0.15 log units) away from the limit.
By their numbers in this assay, from the lowest: compounds 2, 3 and 1 (each within the scatter of the next). At a limit, above all of these: compound 4.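

For the compounds shown here, this is the first reading of this swap on the shared core: with 4-cyanophenyl in place of 5-cyanopyridin-2-yl, this assay gives an at least 1.2-fold higher number from compound 1 to compound 4 (0.10 log units; that floor lies within the scatter). Going by these compounds alone, the result for compound 4 is a limit and not a number, so the true size of the step is unknown: the limit of > 2 h in this assay, at which 1 of the 4 values shown sits. Since even the floor of that step lies within the scatter, the data show only that replacing the ring nitrogen with carbon at this position did not bring the value down, which the hydrogen for methylcarbamoyl step among the earlier compounds could not show.

On these data alone, how far compound 4 really stands from compound 1 remains open, since a limit cannot settle it. Also open, as far as these compounds go, is whether a carboxylic acid or an amine in place of the nitrile on this ring would keep the value of compound 4 in this assay.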